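The compounds below may be only part of what the source reports. "The series", "measured", "known", "first", "only" and "open" are said of these compounds alone.

Working notes on the series. In a functional assay on the whole organism for inhibition, with Rattus norvegicus as the target (on this read-out lower numbers stand for an effect already at smaller amounts and higher numbers for an effect only at larger amounts of compound), compound 1 `CC(C)c1ccc(OC(Cc2ccc(C(F)(F)F)cc2)C(=O)O)cc1` gives 10 mg/kg and compound 2 `CC(C)c1ccc(OC(C)(Cc2cccc(-c3ccccc3)c2)C(=O)O)cc1` gives 0.5 mg/kg as measured numbers. Compound 3 `COc1ccc(Cc2ccc(OC(C)(Cc3ccc(Cl)cc3)C(=O)O)cc2)cc1` stands at < 10 mg/kg in this assay, and that is a limit and not a number. Compound 4 `CC(Cc1ccc(Cl)cc1)(Oc1ccc(C2CCSCC2)cc1)C(=O)O` carries thian-4-yl in place of 4-methoxybenzyl on an aromatic carbon para to a large group, and the count reads thian-4-yl in place of 4-methoxybenzyl on an aromatic carbon for this change. Going by the values given here, no measured step between compounds differing in one place is available to size it. The expected step that the limit leaves unreadable from compound 3 to compound 4 is modest, is toward smaller doses, and is set against a limit only. The expectation lies within the span from compound 2 at 0.5 mg/kg to compound 1 at 10 mg/kg in this assay. Compound 4 is estimated at 3 mg/kg with an expected range from 0.7 mg/kg to 12 mg/kg in this assay.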

Compound 4, dose for half-maximal effect: < 10 mg/kg
Compound 4 was reported as a limit; the forecaster's own chance of this, stated with the estimate: 30%; the middle value does not contradict the limit.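

No step can be read between compound 3 and compound 4, since in this assay both stand as limits and not numbers: the limit of < 10 mg/kg in this assay, at which 2 of the 4 values shown sit. From the compounds shown here alone, whether thian-4-yl in place of 4-methoxybenzyl shifts the dose for half-maximal effect remains open.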